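Hydroxylated cyclic amides on the shared alkyne core

The source may report more compounds than this note shows. Statements on the series, on what has been measured and on what is new or still open speak of the compounds shown alone.

Compound 1 `COc1ccc(C#Cc2ccc(C(=O)N3CCC[C@@H](O)C3)c(F)c2)cc1` and compound 2 `COc1ccc(C#Cc2ccc(C(=O)N3CCCC(C)(O)C3)cc2)cc1` carry six-membered amide rings with the hydroxyl on the ring itself. In a functional assay on TREX cells for negative allosteric modulation of metabotropic glutamate receptor 3 (Rattus norvegicus), read by calcium flux, with a stated time of 2.5 min (a higher number here means a weaker inhibitor, a lower number a stronger inhibitor), compound 1 gives 450 nM; 593 nM; 603 nM (3 entries), and compound 2 gives 711 nM; 1100 nM (2 entries); the spread within each set is shown by the several entries of compound 1 in this assay, 450 nM; 593 nM; 603 nM (3 entries) and (the several entries of compound 2 in this assay, 711 nM; 1100 nM (2 entries)). Compound 3 `COc1ccc(C#Cc2ccc(C(=O)N3CCC(CO)C3)cc2)cc1` carries a five-membered amide ring with the hydroxyl on a carbon outside the ring, and in this assay compound 3 gives 7590 nM. Among the measured compounds shown here, this is the only single number held for compound 3; two further entries of compound 3 in this assay gave no single number.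

Compound 4 `COc1ccc(C#Cc2ccc(C(=O)N3CC[C@@H](O)C3)cc2)cc1` moves the hydroxyl onto the five-membered ring: 3-hydroxypyrrolidin-1-yl in place of 3-(hydroxymethyl)pyrrolidin-1-yl on a carbonyl carbon. For the measured compounds named here, no measured step between two compounds of this kind is at hand, so the expectation rests on the values of compounds 1, 2 and 3 alone. Given the values of compound 1 at 450 nM; 593 nM; 603 nM (3 entries) and compound 2 at 711 nM; 1100 nM (2 entries), both with the hydroxyl on the ring, compound 4 is expected to move toward them, by about a 4.2-fold lower number from compound 3 to compound 4 (0.62 log units; beyond the scatter). Compound 4 is estimated at 1800 nM, within a range from 500 nM to 6000 nM.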

Compound 4, half-maximal inhibitory concentration: 10200 nM
The estimate for compound 4 lay 5.7-fold (0.75 log units) below the measured number, outside the stated range (above it).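

In this assay the step is a 1.3-fold higher number from compound 3 to compound 4 (0.13 log units; within the scatter) for 3-hydroxypyrrolidin-1-yl in place of 3-(hydroxymethyl)pyrrolidin-1-yl on a carbonyl carbon. Among the compounds shown here, on the five-membered amide ring, then, a hydroxyl on the ring itself and a hydroxyl on a carbon outside the ring are not told apart by this read-out, a point that compound 3 alone could not show, and compounds 1 and 2 differ from compound 4 in more than one place, so no step to them can be read. No measurement at hand bears on why compound 3 and compound 4 read alike.

Open, on these data alone, is whether the hydroxyl contributes at all on this five-membered ring, which a plain pyrrolidin-1-yl amide would address, and how the opposite stereocentre of the 3-hydroxypyrrolidin-1-yl group would read. Also open, as far as these compounds go, is how an amine, a carboxylic acid or a longer chain such as 2-hydroxyethyl would read at the same ring carbon, and what the five-membered and six-membered rings do when compared on an otherwise identical core.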